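A few compounds are considered here, and "the series" means these few. Any claim that something is new, unique, unknown or untested is made for them only; others in the source may bear on it.

Among the measured compounds shown here, compound 2 `CC(C)(C)[C@H]1CC[C@]2(CC1)N=C(c1cccc(Cl)c1)C(=O)N2Cc1ccc(C(=O)NCCC(=O)O)cc1` gives 770 nM in an assay on CHO cells for displacement of a labelled ligand from Glucagon receptor (Homo sapiens), read by scintillation counting, with a stated time of 60 min (a higher number here means a weaker inhibitor, a lower number a stronger inhibitor), the higher of the two numbers measured so far; compound 1 `C[C@H](c1ccc(C(=O)NCCC(=O)O)cc1)N1C(=O)C(c2cccc(Cl)c2)=N[C@]12CC[C@@H](C(C)(C)C)CC2` gives 130 nM in this assay, and the step of a 5.9-fold higher number from compound 1 to compound 2 (0.77 log units; beyond the scatter) lies beyond the scatter. Compound 3 `CC(C)(C)[C@H]1CC[C@]2(CC1)N=C(c1ccc(Cl)cc1)C(=O)N2Cc1ccc(C(=O)NCCC(=O)O)cc1` differs from compound 2 in one place: 4-chlorophenyl in place of 3-chlorophenyl on a carbon with a double bond to nitrogen, a 4-chlorophenyl in place of 3-chlorophenyl on a carbon with a double bond to nitrogen. For the measured compounds named here, no measured step touches this change, so no shift beyond the scatter is expected, and the step of a 1.0-fold higher number from compound 2 to compound 3 (0.02 log units; within the scatter) is an estimate resting on compound 2 alone. Compound 3 is therefore expected to give about 800 nM in this assay, within 250 nM to 2500 nM.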

Compound 3, half-maximal inhibitory concentration: 940 nM
The estimate for compound 3 lay 1.2-fold (0.07 log units) below the measured number; the range from low to high includes it.
By their numbers in this assay, from the lowest: compound 1; then compounds 2 and 3 (each within the scatter of the next).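

Placing 4-chlorophenyl in place of 3-chlorophenyl on the carbon with a double bond to nitrogen gives a 1.2-fold higher number from compound 2 to compound 3 (0.09 log units; within the scatter) in this assay, so the two compounds cannot be told apart in this assay. Of these two chlorophenyl groups at this place, then, neither is favoured on this scaffold. Nothing at hand explains this result. As far as these compounds go, it remains open whether a phenyl without chlorine, or a methoxy or nitrile group on that ring, would also stay within the scatter. From the compounds shown here alone, whether 4-chlorophenyl behaves alike with the methyl of compound 1 also remains open.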